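Amide nitrogen substituent exchange: tetrazolylethyl to phenyl

The source may hold more compounds than are shown below. What is called first, only, known or untested is meant among the compounds shown, and "the series" means these compounds.

Measured compounds:
- compound 1 `NCc1cc(Oc2cccc(C(=O)NCc3cc4ccccc4s3)c2)nc(C(F)(F)F)c1`: "not determined" (no result reported) in an ADME assay on the whole organism (lung, Mus musculus) for pharmacokinetics, read by LC-MS, at a dose of 30 mg/kg by the oral route; on this read-out higher numbers stand for higher exposure at the dose given and lower numbers for lower exposure
- compound 2 `NCc1cc(Oc2cccc(C(=O)NCCn3cnnn3)c2)nc(C(F)(F)F)c1`: 3460 nM in this assay

Among the compounds with values here, compound 2 stands as the only numbered entry in this assay; compound 1 carries no result there, so there is no comparison between measured compounds to draw on. Compound 2 itself gives 3460 nM, and that is the sole anchor for the series.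

Compound 3 `NCc1cc(Oc2cccc(C(=O)Nc3ccccc3)c2)nc(C(F)(F)F)c1` has not been measured. It differs from compound 2 in one place: phenyl in place of 2-(1H-tetrazol-1-yl)ethyl on an amide-type nitrogen. The 2-(1H-tetrazol-1-yl)ethyl group on the amide-type nitrogen, whose other neighbour is the carbonyl carbon, leaves, and phenyl enters at the same place.

Within the data shown here, with no step between measured compounds to guide the direction, the working expectation for this assay is a step from compound 2 to compound 3 of no more than the usual scatter, in either direction, as a 1.2-fold lower number from compound 2 to compound 3 (0.06 log units; within the scatter). Among the measured compounds shown here, compound 3 is therefore expected at about 3000 nM, with a plausible range from 900 nM to 10000 nM, the width reflecting how little the single value of compound 2 constrains it.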

Compound 3, maximal plasma concentration: 10300 nM
Beside the measured number, compound 3's estimate is 3.4-fold (0.54 log units) below it, outside the stated range (above it).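

Phenyl in place of 2-(1H-tetrazol-1-yl)ethyl on the amide-type nitrogen gives a 3.0-fold higher number from compound 2 to compound 3 (0.47 log units; beyond the scatter) in this assay, so the group on this nitrogen does bear on the read-out, which a single number could not show. The change takes out a five-membered aromatic ring with 4 hetero atoms, together with its 4 hydrogen-bond acceptors, and puts in a six-membered aromatic ring of carbon only, and the number rises rather than falls: on this one pair, the tetrazole-bearing group is not required for the exposure seen with the shared core. No supporting measurement bears on why the number moves, so the step stands as an observation only.

This single pair does not separate the effect of changing the ring from that of removing the ethyl chain, and a benzyl or 2-phenylethyl group on the same nitrogen would pull those two apart. It also leaves open how far the phenyl ring itself allows substitution, for instance with an aminomethyl group or a carboxylic acid.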